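Lengthening a Chain When Readings Stop at a Limit

The compounds below may be only part of what the source reports. "The series", "measured", "known", "first", "only" and "open" are said of these compounds alone.

Measured in a functional assay for inhibition, with Rattus norvegicus as the target; a lower number here means that less compound is needed, a higher number that more compound is needed for the effect:
- compound 1 `CSCC[C@H](NC(=O)c1ccc(CN[C@H](C)CC2CCCCC2)cc1-c1ccccc1C)C(=O)O` gives the limit > 1000 nM
- compound 2 `CC[C@H](CC1CCCCC1)NCc1ccc(C(=O)N[C@@H](CCSC)C(=O)O)c(-c2ccccc2C)c1` gives the limit > 1000 nM

Compound 1 therefore has no exact number, only a limit. Compound 3 `CCCC[C@H](CC1CCCCC1)NCc1ccc(C(=O)N[C@@H](CCSC)C(=O)O)c(-c2ccccc2C)c1` differs from it by propyl in place of hydrogen on a saturated chain carbon, two bonds along the chain from an amine nitrogen, with propyl in place of hydrogen on a saturated chain carbon, two bonds along the chain from an amine nitrogen. Among the compounds with values here, the one measured step at this place is a step that the two limits leave unreadable from compound 1 to compound 2, with methyl entering instead, so it offers no size to carry over. Both measured compounds share one ceiling, (the limit of > 1000 nM in this assay, at which 2 of the 2 values shown sit). Within the data shown here, no defined step can therefore be forecast in this assay, and another limit is the likeliest result. The expected change is a step that the limit leaves unreadable from compound 1 to compound 3. For compound 3 the estimated value is 2000 nM, with an expected range from 700 nM to 8000 nM.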

Compound 3, half-maximal effective concentration: 4.3 nM
Estimate against measurement, compound 3: 470-fold (2.67 log units) above; measured number outside the range, below it.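

In this assay, the earlier compounds gave only a shared limit, and the step between them cannot be read, so they could not show whether this chain matters: the limit of > 1000 nM in this assay, at which 2 of the 3 values shown sit.

Compound 3 settles that, with propyl in place of hydrogen on a saturated chain carbon, two bonds along the chain from an amine nitrogen, giving an at least 230-fold lower number from compound 1 to compound 3 (2.36 log units; beyond the scatter). Ethyl in place of hydrogen on a saturated chain carbon, three bonds along the chain from an amine nitrogen, gives an at least 230-fold lower number from compound 2 to compound 3 (2.36 log units; beyond the scatter), so among these three compounds only the one carrying the butyl group has a measured number.

As far as these compounds go, whether a propyl or pentyl group at this place would also give a low number remains open. So does whether the gain needs a straight chain or would survive with a branched isobutyl group.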